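Adding a Second Chlorine to the Piperazine Aryl Group

A few compounds are considered here, and "the series" means these few. Any claim that something is new, unique, unknown or untested is made for them only; others in the source may bear on it.

Two oxazole amides have been tested in a functional assay on HL-60 cells (Homo sapiens) for inhibition, read by MTT assay, with a stated time of 72 h; on this read-out higher numbers stand for weaker inhibition and lower numbers for stronger inhibition. Compound 1 `O=C(c1oc(C(F)(F)F)nc1-c1cccc(Cl)c1)N1CCN(c2cccc(Cl)c2)CC1` gives "not active" (no number reported), with no number reported. Compound 2 `Cc1nc(-c2ccccc2)c(C(=O)N2CCN(c3ccccc3Cl)CC2)o1` gives 124 nM, the only number shown, so no ranking among measured compounds is possible. Compound 3 `Cc1nc(-c2ccccc2)c(C(=O)N2CCN(c3ccc(Cl)c(Cl)c3)CC2)o1` is the next candidate; its change from compound 2 is 3,4-dichlorophenyl in place of 2-chlorophenyl on an amine nitrogen in a ring. For the measured compounds named here, no measured pair shows what this change does, so the step is expected to be modest, likely a slight weakening, as a 2.0-fold higher number from compound 2 to compound 3 (0.30 log units; within the scatter). For compound 3 the estimated value in this assay is 250 nM, within a range from 60 nM to 2000 nM.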

Compound 3, half-maximal inhibitory concentration: 124 nM
Estimate against measurement, compound 3: 2.0-fold (0.30 log units) above, and the stated range covers the measured number.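

Replacing 2-chlorophenyl with 3,4-dichlorophenyl on the ring amine nitrogen gives no change at the digits printed from compound 2 to compound 3 (within the scatter) in this assay. This first measured step at this position shows that the aryl group there can carry a second chlorine without a change in the number that can be told from scatter. Nothing at hand explains why the number holds.

Still open, going by these compounds, is whether an unsubstituted phenyl, a methoxyphenyl or a pyridine would hold the number too. Compound 1 has no number, so it cannot show whether the same tolerance applies on its core.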